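A few compounds are considered here, and "the series" means these few. Any claim that something is new, unique, unknown or untested is made for them only; others in the source may bear on it.

Series notes. In a functional assay on MIA PaCa-2 cells (Homo sapiens) for inhibition, read by MTT assay, with a stated time of 7 days (on this read-out higher numbers stand for weaker inhibition and lower numbers for stronger inhibition), compound 3 `CCN(CC)C(=O)c1ccc(S(=O)(=O)N2CCC[C@@H](C(=O)N3CCC(F)(F)CC3)C2)cc1` gives 70 nM, the second highest of the three numbers: compound 1 `O=C([C@@H]1CCCN(S(=O)(=O)c2ccc(S(=O)(=O)N3CC[C@@H](O)C3)cc2)C1)N1CCC(F)(F)CC1` gives 210 nM and compound 2 `CCC(CC)S(=O)(=O)c1ccc(S(=O)(=O)N2CCC[C@@H](C(=O)N3CCC(F)(F)CC3)C2)cc1` gives 13 nM. Compound 4 `O=C([C@@H]1CCCN(S(=O)(=O)c2ccc(S(=O)(=O)C3CC3)cc2)C1)N1CCC(F)(F)CC1` carries cyclopropylsulfonyl in place of diethylcarbamoyl on an aromatic carbon. Going by the values given here, the steps that bear on this are a 5.4-fold higher number from compound 2 to compound 3 (0.73 log units; beyond the scatter), a 3.0-fold lower number from compound 1 to compound 3 (0.48 log units; beyond the scatter) and a 16-fold lower number from compound 1 to compound 2 (1.21 log units; beyond the scatter); the (pentan-3-yl)sulfonyl of compound 2 gave the lowest number, the diethylcarbamoyl of compound 3 sat between it and the (3-hydroxypyrrolidin-1-yl)sulfonyl of compound 1. Since the entering group is again a sulfonyl carrying only carbon, a modest step down is expected for compound 4, a 2.3-fold lower number from compound 3 to compound 4 (0.37 log units; beyond the scatter). Compound 4 is therefore estimated at 30 nM in this assay, with a range from 10 nM to 100 nM.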

Compound 4, half-maximal inhibitory concentration: 26 nM
Compound 4: middle estimate off by 1.2-fold (0.06 log units), on the high side; measured number inside the range.
By their numbers in this assay, from the lowest: compounds 2 and 4 (each within the scatter of the next); then compound 3; then compound 1.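

In this assay a second carbon-only sulfonyl on this aromatic carbon gives a low number: the cyclopropylsulfonyl of compound 4 shows a 2.7-fold lower number from compound 3 to compound 4 (0.43 log units; beyond the scatter) and an 8.1-fold lower number from compound 1 to compound 4 (0.91 log units; beyond the scatter) in the comparison with the sulfonamide. On the sulfonyl sulfur, cyclopropyl and pentan-3-yl cannot be told apart, with a 2.0-fold higher number from compound 2 to compound 4 (0.30 log units; within the scatter) as the step, so the branched open chain is not required here. No measurement shown accounts for these steps.

Still open, from the compounds shown here alone, is whether a phenyl or a longer straight chain on the sulfonyl sulfur holds the number. Also open, going by these compounds, is how an amine or a carboxylic acid at the end of such a chain would read.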